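The compounds below may be only part of what the source reports. "The series", "measured", "known", "first", "only" and "open" are said of these compounds alone.

In a physicochemical assay for lipophilicity (on this read-out lower numbers stand for lower lipophilicity and higher numbers for higher lipophilicity), compound 2 `CC(C)(C)C#Cc1cc(N(C(=O)[C@H]2CC[C@H](C)CC2)[C@H]2CC[C@H](OC3CCOC3)CC2)c(C(=O)O)s1` gives 2.3 and compound 1 `CC(C)(C)C#Cc1cc(N(C(=O)[C@H]2CC[C@H](C)CC2)[C@H]2CC[C@H](Oc3ccc4nccn4n3)CC2)c(C(=O)O)s1` gives 2.4, two values within the scatter of each other. Compound 3 `C[C@@H]1CC[C@@H](C(=O)N(c2cc(C#CC(C)(C)C)sc2C(=O)O)[C@H]2CC[C@H](OC3CCOC3)CC2)[C@@H](O)C1` departs from compound 2 at one place: hydroxy in place of hydrogen on a saturated ring carbon. For the measured compounds named here, the only measured step, a number 0.10 log units lower from compound 1 to compound 2 (within the scatter), exchanges a group on an oxygen and does not touch this ring carbon, so it offers no direct guide. With hydroxy in place of hydrogen on a saturated ring carbon, a moderate move to a lower number is expected, an estimated a number 0.50 log units lower from compound 2 to compound 3 (beyond the scatter). The estimate for compound 3 is 1.8, with an expected range from 1.3 to 2.3.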

Compound 3, distribution coefficient: 2.2
For compound 3 the middle estimate is 0.40 log units below the measured one, within the range that was stated.
By their numbers in this assay, from the lowest: compounds 3, 2 and 1 (each within the scatter of the next).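

In this assay, hydroxy in place of hydrogen on the saturated ring carbon gives a number 0.10 log units lower from compound 2 to compound 3 (within the scatter), so at this place the change from 4-methylcyclohexyl to 2-hydroxy-4-methylcyclohexyl leaves no difference that stands clear of the scatter. Compound 1 and compound 2 both carry 4-methylcyclohexyl and so showed nothing about this ring. No available evidence explains this result. As far as these compounds go, whether an amine or a methoxy group on this ring carbon would also stay within the scatter of compound 2 remains open. So does the outcome for hydroxy on another carbon of this ring.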